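Methoxy addition in a cytotoxicity series

The source may report more compounds than this note shows. Statements on the series, on what has been measured and on what is new or still open speak of the compounds shown alone.

Measured compounds:
compound 1 `COc1ccc(/C=C2\CCC/C(=C\c3cccc(OC)c3OC)C2=O)cc1` — a limit of the assay, > 20000 nM
compound 2 `COc1ccc(/C=C2\CCC/C(=C\c3cccc(OC)c3OC)C2=O)c(OC)c1` — a limit of the assay, > 20000 nM
compound 3 `COc1cc(/C=C2\CCC/C(=C\c3cccc(OC)c3OC)C2=O)cc(OC)c1` — 10200 nM

In a functional assay on A549 cells (Homo sapiens) for cytotoxicity, read by MTT assay, with a stated time of 72 h (on this read-out higher numbers stand for weaker inhibition and lower numbers for stronger inhibition), compound 1 returns only a limit, > 20000 nM. Compound 2 likewise returns only a limit in this assay, > 20000 nM. The change between them is methoxy in place of hydrogen on an aromatic carbon, and the step that the two limits leave unreadable from compound 1 to compound 2 cannot be read in size because of the limit of > 20000 nM in this assay, at which 2 of the 3 values shown sit. For the measured compounds named here, compound 3 is the one compound with a number in this assay, where compound 3 gives 10200 nM. The difference between the core of compound 1 and the core of compound 3 is not broken down here.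

Compound 4 `COc1cccc(/C=C2\CCC/C(=C\c3cc(OC)c(OC)c(OC)c3)C2=O)c1OC` has not been measured in this assay. It differs from compound 3 by methoxy in place of hydrogen on an aromatic carbon. This is the same kind of change as that from compound 1 to compound 2, though not the same: in compound 4 the entering methoxy sits ortho to two methoxy groups and para to a large group, whereas in compound 2 it sits ortho to a large group and meta to a methoxy group. Going by the values given here, the one measured instance of this kind of change gives no readable size, so the expected step of a 1.0-fold lower number from compound 3 to compound 4 (0.01 log units; within the scatter) is set small, near no change, resting on compound 3 at 10200 nM as the starting point. Compound 4 is therefore estimated at 10000 nM, with a range expected from 3000 nM to 30000 nM, and a real chance that only a limit is returned.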

Compound 4, half-maximal inhibitory concentration: 5900 nM
Beside the measured number, compound 4's estimate is 1.7-fold (0.23 log units) above it; the measured number falls inside the stated range.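

In this assay, methoxy in place of hydrogen on an aromatic carbon, here ortho to two methoxy groups and para to a large group, gives a 1.7-fold lower number from compound 3 to compound 4 (0.24 log units; within the scatter), so on this core the two values cannot be told apart. For the compounds shown here, the only other instance of this kind of change, from compound 1 to compound 2 on a different core, cannot be read in size, and the entering methoxy also sits in a different place there: the limit of > 20000 nM in this assay, at which 2 of the 4 values shown sit. Going by these compounds alone, the series therefore offers no two readable steps to set side by side, so it neither shows that the result on the core of compound 3 carries over to the core of compound 1 nor shows that it fails to carry over.

All the aromatic groups shown bear methoxy alone, so the effect in this assay of a hydroxy group, an amine or a carboxylic acid at the same place, or of a longer chain such as ethoxy, remains open. Also open, going by these compounds, is how far compound 1 and compound 2 lie from a measurable number, and whether any readable step for this change can be obtained on their core.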